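The compounds below may be only part of what the source reports. "The series", "measured", "known", "first", "only" and "open" are said of these compounds alone.

Measured so far in a functional assay on K562 cells (Homo sapiens) for antiproliferative activity, read by trypan blue exclusion, with a stated time of 48 h, tested at 10 uM; on this read-out lower numbers stand for less inhibition of growth and higher numbers for more inhibition of growth at the one concentration tested:

compound 1, `NC(=O)c1cc(Cl)ccc1NC(=O)/C=C/c1cccc(Br)c1`, gives 27%
compound 2, `Cc1ccccc1/C=C/C(=O)Nc1ccc(Cl)cc1C(N)=O`, gives 52.2%
compound 3, `NC(=O)c1cc(Br)ccc1NC(=O)/C=C/c1cccc(Br)c1`, gives 45.9%

Two single changes connect these three compounds. The first is 2-methylphenyl in place of 3-bromophenyl on a double-bonded chain carbon bound to a double-bonded chain carbon, and it made a step of a number 25.2 percentage points higher from compound 1 to compound 2 (beyond the scatter). The second is the change between the two cores, (bromo in place of chloro on an aromatic carbon), which made a step of a number 18.9 percentage points higher from compound 1 to compound 3 (beyond the scatter). Compound 2 and compound 3 sit close to one another, within the usual scatter, so no order is claimed between them; only compound 1 stands apart from both.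

Compound 4, `Cc1ccccc1/C=C/C(=O)Nc1ccc(Br)cc1C(N)=O`, has not yet been measured. It differs from compound 3 by 2-methylphenyl in place of 3-bromophenyl on a double-bonded chain carbon bound to a double-bonded chain carbon, the same change already seen from compound 1 to compound 2, made here on the core that carries bromo in place of chloro. Among the compounds shown this change occurs twice in all, and only one instance is measured.

For compound 4 a step of a number 16.1 percentage points higher from compound 3 to compound 4 (beyond the scatter) is expected, set beside the earlier a number 25.2 percentage points higher from compound 1 to compound 2 (beyond the scatter). This expectation rests on that single measured step from compound 1 to compound 2 and on the starting point of compound 3 at 45.9%. The estimate is somewhat smaller than the earlier step, since compound 3 already starts higher than compound 1 did, and a single instance gives little assurance that the full step repeats. Compound 4 is therefore expected to give about 62%, most likely between 45% and 80%.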

Compound 4, percent growth inhibition at one concentration: 43.2%
For compound 4 the middle estimate is 18.8 percentage points above the measured one, and the stated range ends above it.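

On the core that carries bromo, 2-methylphenyl in place of 3-bromophenyl made a step of a number 2.7 percentage points lower from compound 3 to compound 4 (within the scatter) in this assay, so the step seen on the core that carries chloro did not carry over to this core: the same change on two cores in this assay, a number 25.2 percentage points higher (beyond the scatter) from compound 1 to compound 2 and a number 2.7 percentage points lower (within the scatter) from compound 3 to compound 4, 27.9 percentage points apart, beyond the scatter of two such steps. Read along the other edge of the same four compounds, bromo in place of chloro on an aromatic carbon made a step of a number 9 percentage points lower from compound 2 to compound 4 (within the scatter), which likewise differs from the step measured with 3-bromophenyl in the molecule: the same change on two cores in this assay, a number 18.9 percentage points higher (beyond the scatter) from compound 1 to compound 3 and a number 9 percentage points lower (within the scatter) from compound 2 to compound 4, 27.9 percentage points apart, beyond the scatter of two such steps. These two comparisons are one finding seen from two sides: in these four compounds the two changes do not add, and the effect of each depends on what stands at the other place, but a single set of four compounds does not show why this happens or whether it holds for any other pair of groups.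

The compounds shown leave open whether other groups on the double-bonded chain carbon, such as an unsubstituted phenyl or a methoxyphenyl, would behave like 2-methylphenyl or like 3-bromophenyl on the two cores. They also leave open how a fluoro group in place of chloro or bromo, or a carboxylic acid in place of the primary amide, would alter these steps.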